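The source may hold more compounds than are shown below. What is called first, only, known or untested is meant among the compounds shown, and "the series" means these compounds.

Working notes on the series. In a functional assay on SK-OV-3 cells (Homo sapiens) for antiproliferative activity, read by MTT assay, with a stated time of 72 h (on this read-out lower numbers stand for stronger inhibition and higher numbers for weaker inhibition), compound 1 `O=C(CCc1cccc2c1B(O)OC2)NCc1ccccc1` gives > 100000 nM, which is a limit and not a number. Compound 1 thus sits at the limit of > 100000 nM in this assay, at which 2 of the 3 values shown sit. Compound 2 `CC(C)(C)OC(=O)Nc1ccc(NC(=O)CCc2cccc3c2B(O)OC3)cc1` gives > 100000 nM, again a limit. Compound 3 `O=C(CCc1cccc2c1B(O)OC2)Nc1ccc([N+](=O)[O-])cc1` gives 83000 nM. Going by the values given here, the one measured step is an at least 1.2-fold lower number from compound 2 to compound 3 (0.08 log units; that floor lies within the scatter); it is a different swap and bears only loosely on what follows. Compound 4 `O=C(CCc1cccc2c1B(O)OC2)Nc1cccc(Br)c1` differs from compound 1 by 3-bromophenyl in place of benzyl on an amide-type nitrogen. Among the compounds with values here, with compound 3 at 83000 nM as the only number so far, a small step to a lower number in this assay is expected. For compound 4 a reading at the limit remains possible. The expected step is an at least 2.0-fold lower number from compound 1 to compound 4 (0.30 log units; that floor lies within the scatter). For compound 4 the estimated value is 50000 nM, with an expected range of 15000 nM to 120000 nM.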

Compound 4, half-maximal inhibitory concentration: 540 nM
Beside the measured number, compound 4's estimate is 93-fold (1.97 log units) above it; measured number outside the range, below it.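

In this assay, 3-bromophenyl in place of benzyl on an amide-type nitrogen gives an at least 180-fold lower number from compound 1 to compound 4 (2.26 log units; beyond the scatter). This place can therefore carry a large step, although the heavy-atom count stays the same and one six-membered aromatic ring of carbon only leaves as another enters. The value for compound 1 is a limit: the limit of > 100000 nM in this assay, at which 2 of the 4 values shown sit.

The compounds shown do not separate the contribution of the bromine from that of replacing benzyl with a phenyl ring. Also open, as far as these compounds go, is what an amine or a carboxylic acid in place of the bromine would give.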